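Methyl to methoxy on the anilino ring of compound 1

The source may hold more compounds than are shown below. What is called first, only, known or untested is meant among the compounds shown, and "the series" means these compounds.

For the measured compounds named here, compound 1 `Cc1ccc(NC2=CC(=O)c3nc4n(c3C2=O)[C@H]2OC[C@@H](O)[C@H]2OC4)cc1` is the one member of the series with a number in a functional assay on ECa-109 cells for inhibition, with ECa-109 cell line (Homo sapiens) as the target, read by sulforhodamine B assay (a lower number here means a stronger inhibitor, a higher number a weaker inhibitor), where compound 1 gives 3480 nM. Compound 2 `O=C1C(N2CCCCC2)=CC(=O)c2c1nc1n2[C@H]2OC[C@@H](O)[C@H]2OC1` reaches only a limit in this assay, compound 2 giving > 8000 nM (the limit of > 8000 nM in this assay, at which 1 of the 3 values shown sits). Compound 3 `Cc1ccc(NC2=CC(=O)c3c(nc4n3[C@H]3OC[C@@H](O)[C@H]3OC4)C2=O)cc1` likewise ends at a limit, compound 3 giving > 4000 nM (the limit of > 4000 nM in this assay, at which 1 of the 3 values shown sits). Going by the values given here, the single step within the measured set, a step that the two limits leave unreadable from compound 2 to compound 3, thus cannot be sized.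

Compound 4 `COc1ccc(NC2=CC(=O)c3nc4n(c3C2=O)[C@H]2OC[C@@H](O)[C@H]2OC4)cc1` differs from compound 1 by methoxy in place of methyl on an aromatic carbon. Among the compounds with values here, no measured step touches this change: the one step on record concerns the amine on the double-bonded ring carbon, not a substituent on the aryl ring, and it is unreadable anyway. Without a comparable step, the expectation for compound 4 in this assay is a change no larger than the scatter, in no set direction, so the estimated step of a 1.0-fold higher number from compound 1 to compound 4 (0.00 log units; within the scatter) is expected to be small. Compound 4 is therefore estimated at 3500 nM, with an expected range from 1500 nM to 8000 nM.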

Compound 4, half-maximal inhibitory concentration: > 4000 nM
Compound 4: a limit, no number (the forecaster's own chance of this, stated with the estimate: 30%); middle value at least 1.1-fold (0.05 log units) from the limit.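

For the compounds shown here, the change from 4-methylphenyl to 4-methoxyphenyl gives the first reading for a substituent on this aromatic ring in this assay: the swap gives an at least 1.1-fold higher number from compound 1 to compound 4 (0.06 log units; that floor lies within the scatter). Because that floor lies within the scatter, the step neither establishes a real loss on adding the methoxy oxygen nor rules out a larger one. Compound 4 gives > 4000 nM, which is a limit and not a number: the limit of > 4000 nM in this assay, at which 2 of the 4 values shown sit.

On these data alone, the true size of the step remains open, and the step from compound 2 to compound 3 cannot be read either. Also open, as far as these compounds go, is how a chlorine, a hydroxyl or a carboxylic acid would read in place of the methyl of compound 1.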